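Phenyl in place of tert-butyl: an estimate for compound 4

A few compounds are considered here, and "the series" means these few. Any claim that something is new, unique, unknown or untested is made for them only; others in the source may bear on it.

In a functional assay on a cell-free system (plasma, Homo sapiens), with a stated time of 3 min (a higher number here means a weaker inhibitor, a lower number a stronger inhibitor), compound 1 (`CC(C)(C)[C@@H](O)C(=O)N1OCC[C@H]1C(=O)NCc1cc(Cl)ccc1-n1cnnn1`) gives 1600 nM and is clearly separated from only one of the two other measured compounds. Compound 2 (`O=C(NCc1cc(Cl)ccc1-n1cnnn1)[C@@H]1CCNN1C(=O)[C@H](O)c1ccccc1`) gives 930 nM and lies within the usual scatter of compound 1. Compound 3 (`CC(C)(C)C[C@@H](O)C(=O)N1[C@@H]2C[C@@H]2C[C@H]1C(=O)NCc1cc(Cl)ccc1-n1cnnn1`) gives 520 nM and has a lower number than compound 1 by more than the scatter.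

Compound 4 (`O=C(NCc1cc(Cl)ccc1-n1cnnn1)[C@@H]1CCON1C(=O)[C@H](O)c1ccccc1`) has not yet been measured. It carries phenyl in place of tert-butyl on a saturated chain carbon bound to a carbonyl carbon and an oxygen on a saturated carbon. Within the data shown here, no measured pair isolates this change. Compound 2 also carries hydroxy(phenyl)methyl, on a different core, and its 930 nM reading cannot be told apart from that of compound 1. The step expected in this assay is a 1.6-fold lower number from compound 1 to compound 4 (0.20 log units; within the scatter) and so stays within the scatter, with a lower number the likelier direction. Compound 4 is estimated at 1000 nM with 350 nM to 2800 nM as the expected range.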

Compound 4, half-maximal inhibitory concentration: 1500 nM
The estimate for compound 4 lay 1.5-fold (0.18 log units) below the measured number; measured number inside the range.
By their numbers in this assay, from the lowest: compounds 3, 2, 4 and 1 (each within the scatter of the next, the first and the last beyond it).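

In this assay, among these compounds, phenyl in place of tert-butyl on a saturated chain carbon bound to a carbonyl carbon and an oxygen on a saturated carbon gives a 1.1-fold lower number from compound 1 to compound 4 (0.03 log units; within the scatter) and provides the first reading of this change with the rest of the structure held constant. On the core of compound 1, the two groups therefore cannot be told apart in this read-out, even though phenyl brings a six-membered aromatic ring and more heavy atoms to this position. No measurement here bears on why they read alike.

Going by these compounds, whether phenyl and tert-butyl would also read alike on the cores of compound 2 or compound 3 remains open. So does the outcome of placing an amine, a carboxylic acid or a longer chain on this same carbon.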